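The source may hold more compounds than are shown below. What is called first, only, known or untested is meant among the compounds shown, and "the series" means these compounds.

In an ADME assay on Vero cells (Chlorocebus sabaeus) for cytotoxicity, read by MTT assay, with a stated time of 72 h (a higher number here means that more compound is tolerated, a lower number that less compound is tolerated), compound 1 `C/C(=N\NC(=O)c1ccc([N+](=O)[O-])o1)c1ccc(Br)cc1` gives > 177000 nM, which is a limit and not a number. Among the compounds with values here, compound 2 `C/C(=N\NC(=O)c1ccc([N+](=O)[O-])o1)c1ccc(F)cc1` gives 215000 nM, the only actual number so far, so there is no second measured value to rank it against. The next compound, compound 3 `C/C(=N\NC(=O)c1ccc([N+](=O)[O-])o1)c1ccc(C)cc1`, differs from compound 2 at one place: methyl in place of fluoro on an aromatic carbon. In words, this is methyl in place of fluoro on an aromatic carbon, para to a large group. Within the data shown here, only one measured step bears on this change, a step that the limit leaves unreadable from compound 1 to compound 2, which swaps the group at that same place. It gives no usable size, so the expectation rests on compound 2 at 215000 nM, with no change beyond the usual scatter expected in this assay in either direction. The expected step is a 1.1-fold lower number from compound 2 to compound 3 (0.03 log units; within the scatter). For compound 3 the estimated value is 200000 nM, with an expected range from 100000 nM to 400000 nM.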

Compound 3, half-maximal cytotoxic concentration: > 217000 nM
Compound 3 was reported as a limit; the forecaster's own chance of this, stated with the estimate: 35%; middle value at least 1.0-fold (0.03 log units) from the limit.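

Placing methyl where fluoro stood, on an aromatic carbon para to a large group, gives a number no lower from compound 2 to compound 3 (the limit leaves the size open) in this assay, so this change now has a direction, which the earlier step at this place did not provide. Compound 3 gives > 217000 nM, which is a limit and not a number. The steps that involve compound 1 cannot be read, so bromo cannot be ranked against fluoro or methyl.

Fluoro, bromo and methyl have not yet revealed a group at this place that clearly lowers the number in this assay, and how an amine or a carboxylic acid there would behave remains open. As far as these compounds go, how far methyl raises the number, if it does so at all, also remains unknown.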